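Permeability notes: benzyl-end change from compound 3 to compound 4

The compounds below may be only part of what the source reports. "The series", "measured", "known", "first", "only" and "open" are said of these compounds alone.

Measured so far in an ADME assay for permeability, using PAMPA, with a stated time of 30 min, at pH 7.4; a lower number here means that the compound crosses the layer more slowly, a higher number that the compound crosses the layer faster:
compound 1 `COc1cccc(Oc2ccc3c(NCCCNCc4cc(F)ccc4OC)ccnc3c2)c1` gives 317 10^-6 cm/s
compound 2 `CCC(CC)c1ccc2c(NCCCNCc3cc(F)ccc3OC)ccnc2c1` gives 23 10^-6 cm/s
compound 3 `CN(C)c1cccc(Oc2ccc3c(NCCCNCc4ccco4)ccnc3c2)c1` gives 317 10^-6 cm/s

Compound 3 stands level with compound 1 at the digits given; together the two are the highest of the three numbers, and compound 2 lies well below both. Among the compounds with values here, the only single-point step measured, a 14-fold lower number from compound 1 to compound 2 (1.14 log units; beyond the scatter), sits on an aromatic carbon, a different place from the change considered here. Compound 4 `COc1ccc(F)cc1CNCCCNc1ccnc2cc(Oc3cccc(N(C)C)c3)ccc12` differs from compound 3 by 5-fluoro-2-methoxyphenyl in place of furan-2-yl on a saturated chain carbon bound to an amine nitrogen. Within the data shown here, no measured step covers this change directly; compound 1 already carries the 5-fluoro-2-methoxybenzyl group and reads the same as compound 3, though it differs from compound 3 in a second place too. The expectation for compound 4 in this assay is therefore a step of a 1.1-fold lower number from compound 3 to compound 4 (0.02 log units; within the scatter), within the scatter. Compound 4 is estimated at 300 10^-6 cm/s, with a range from 150 10^-6 cm/s to 600 10^-6 cm/s.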

Compound 4, apparent permeability: 317 10^-6 cm/s
Beside the measured number, compound 4's estimate is 1.1-fold (0.02 log units) below it; the range from low to high includes it.
By their numbers in this assay, from the lowest: compound 2; then compounds 1, 3 and 4 (each within the scatter of the next).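

In this assay, within the data shown here, the step at this position reads no change at the digits printed from compound 3 to compound 4 (within the scatter) when 5-fluoro-2-methoxyphenyl enters in place of furan-2-yl, the first direct reading on a saturated chain carbon bound to an amine nitrogen. Dimethylamino in place of methoxy on an aromatic carbon likewise gives no change at the digits printed from compound 1 to compound 4 (within the scatter) and 3-(dimethylamino)phenoxy in place of pentan-3-yl gives a 14-fold higher number from compound 2 to compound 4 (1.14 log units; beyond the scatter) as the large step. Among these compounds, only the change on the aromatic carbon that removes the phenoxy group moves the number beyond the scatter.

From the compounds shown here alone, whether a carboxylic acid or a saturated amine at the chain position would hold the number remains open. Nothing at hand accounts for these steps.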